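Moving the carboxylic acid along the chain-linked phenyl ring

The source may report more compounds than this note shows. Statements on the series, on what has been measured and on what is new or still open speak of the compounds shown alone.

Measured so far:
compound 1, `COc1cc(C(=O)O)ccc1OCCCCOc1ccc(C(=O)C(C)C)c(O)c1C`, 25.6%
compound 2, `Cc1c(OCCCCOc2ccccc2C(=O)O)ccc(C(=O)CC2CCCC2)c1C`, 28%
compound 3, `Cc1c(OCCCCOc2ccccc2C(=O)O)ccc(C(=O)CC2CCCC2)c1O`, 32.9%

In an assay on HEK293 cells for positive allosteric modulation of metabotropic glutamate receptor 3 (Rattus norvegicus), read by thallium flux, with a stated time of 2.5 min (a higher number here means a larger maximal response, a lower number a smaller maximal response), compound 2 stands second highest of the three numbers, and both neighbours lie within the usual scatter of it: compound 1 gives 25.6%, compound 3 gives 32.9%. Going by the values given here, the only single-change step among the measured compounds, a number 4.9 percentage points higher from compound 2 to compound 3 (within the scatter), concerns the hydroxy in place of methyl on an aromatic carbon and says nothing about the carboxylic acid.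

Compound 4, `Cc1c(OCCCCOc2ccc(C(=O)O)cc2)ccc(C(=O)CC2CCCC2)c1C`, has not yet been measured. It differs from compound 2 as follows:

4-carboxyphenyl in place of 2-carboxyphenyl on an oxygen on a saturated carbon

Among the compounds with values here, no measured pair tests this change on its own. Compound 1 also carries its carboxylic acid at a different place on its phenyl ring, but it differs from compound 2 in further ways, so its value only shows that it and compound 2 lie within the scatter of each other. Within the data shown here, with no step that bears directly on the change, the expectation for compound 4 in this assay is a step of about no change at the digits printed from compound 2 to compound 4 (within the scatter), that is none beyond the scatter. Compound 4 is therefore estimated at 28%, with a range from 15% to 42%.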

Compound 4, largest response reached (reported as percent of maximum), in percent of the reference or control that the assay uses: 12.2%
Estimate against measurement, compound 4: 15.8 percentage points above; the whole stated range lies above it.
By their numbers in this assay, from the lowest: compound 4; then compounds 1, 2 and 3 (each within the scatter of the next).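

In this assay, putting 4-carboxyphenyl in place of 2-carboxyphenyl on an oxygen on a saturated carbon gives a number 15.8 percentage points lower from compound 2 to compound 4 (beyond the scatter) and is the only single change shown that moves the maximal response beyond the scatter, whereas the earlier step, a number 4.9 percentage points higher from compound 2 to compound 3 (within the scatter), did not. Going by these compounds alone, the groups that leave and enter have the same heavy atoms, hydrogen-bond donor and acceptor counts and net charge, so compound 2 and compound 4 differ only in where the carboxylic acid sits on the phenyl ring, and this position therefore matters to the response in a way the earlier compounds could not show. Nothing available accounts for the size or direction of this step.

From the compounds shown here alone, it remains open whether the same move would have a similar effect on the core of compound 3, which carries hydroxy in place of methyl, and whether a methyl ester or an amide in place of the carboxylic acid would keep the response of compound 2 at 28%. Going by these compounds, how a longer chain between the two oxygens would affect either acid placement also remains open.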